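Swapping Methoxy for Fluoro on a Shared Core

This account rests on a few compounds, and the source may have more. Where it says the series, first, only, none or still open, it means among the compounds named here.

Of the compounds shown here, two have so far been measured in a functional assay on DLD-1 cells (Homo sapiens) for cytotoxicity, read by colorimetric assay and MTT assay, with a stated time of 3 days, tested at 20 uM; a lower number here means a stronger effect, a higher number a weaker effect of the compound at the concentration tested. Compound 1, `COc1ccc(-c2nc(-c3ccccc3)c(-c3ccc4c(c3)NC(=O)CO4)[nH]2)cc1`, gives 19.1%, the lowest of the two numbers and so the stronger effect of the pair. Compound 2, `O=C1COc2ccc(-c3nn(-c4ccc(Br)cc4)cc3-c3ccccc3)cc2N1`, gives 54.2%, a number that lies above compound 1 by more than the usual scatter. Compound 2 differs from compound 1 in more than one place, so its value says nothing on its own about any single change.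

Compound 3, `O=C1COc2ccc(-c3[nH]c(-c4ccc(F)cc4)nc3-c3ccccc3)cc2N1`, has not yet been measured. It differs from compound 1 in one place only: fluoro in place of methoxy on an aromatic carbon. Cut one bond further out, the change reads 4-methoxyphenyl to 4-fluorophenyl, sitting para to a large group on the shared core.

Among the compounds with values here, no measured pair isolates this swap, so there is no direct guide to its size. The expectation is a small step in this assay, not beyond the scatter, leaning slightly toward a weaker effect. Compound 3 is estimated to give about 25%, in a range from 10% to 45%. That estimate corresponds to an expected step of a number 5.9 percentage points higher from compound 1 to compound 3 (within the scatter), which would stay within the usual scatter.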

Compound 3, a percentage reported as activity, at one concentration (the size of the read-out at that concentration, not a potency): 29.5%
Compound 3: middle estimate off by 4.5 percentage points, on the low side; the range from low to high includes it.
By their numbers in this assay, from the lowest: compound 1; then compound 3; then compound 2.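

Fluoro in place of methoxy on an aromatic carbon, para to a large group, gives a step of a number 10.4 percentage points higher from compound 1 to compound 3 (beyond the scatter) in this assay. Within the data shown here, nothing else on the shared core changes, so this is the first direct reading of this position. This position therefore responds to the swap, with 4-methoxyphenyl going with the stronger effect in this pair, although the step is modest and compound 3 stands at 29.5%. No measurement offered here explains the step or ties it to any particular feature of either group.

Going by these compounds, a single swap gives only two points at this position, so it remains open how the number would move with an amine, a hydroxyl group, or a longer chain such as ethoxy in the same place. On these data alone, it is also open whether fluoro in place of methoxy would give a step of similar size and direction on another core, or at another place on this one.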